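A few compounds are considered here, and "the series" means these few. Any claim that something is new, unique, unknown or untested is made for them only; others in the source may bear on it.

Measured in a functional assay on MCF7 cells (Homo sapiens) for antiproliferative activity, read by MTT assay, with a stated time of 72 h; a higher number here means a weaker inhibitor, a lower number a stronger inhibitor:
- compound 1 `C=CC(=O)Nc1cccc(Oc2nc(Nc3ccn(C)n3)nc3c2CSCC3)c1`: > 50000 nM (a limit of the assay)
- compound 2 `C/C=C/C(=O)Nc1cccc(Oc2nc(Nc3ccn(C)n3)nc3c2CSCC3)c1`: 40000 nM
- compound 3 `CC/C=C/C(=O)Nc1cccc(Oc2nc(Nc3ccn(C)n3)nc3c2CSCC3)c1`: > 50000 nM (a limit of the assay)

For the measured compounds named here, compound 2 gives 40000 nM, the only actual number in the set. Compound 1 and compound 3 both stand at the limit of > 50000 nM in this assay, at which 2 of the 3 values shown sit.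

The next step starts from compound 2 and leads to compound 4 `C/C=C/C(=O)Nc1cccc(Oc2nc(Nc3ccc(OC)nc3)nc3c2CSCC3)c1`. The change is 6-methoxypyridin-3-yl in place of 1-methyl-1H-pyrazol-3-yl on a nitrogen on an aromatic ring.

Going by the values given here, no measured step touches this group. All three lie on the carbonyl side: an at least 1.2-fold lower number from compound 1 to compound 2 (0.09 log units; that floor lies within the scatter), an at least 1.2-fold higher number from compound 2 to compound 3 (0.09 log units; that floor lies within the scatter) and a step that the two limits leave unreadable from compound 1 to compound 3. They bear on the new change only indirectly, as a record that the series has so far stayed near the limit of this assay. Among the compounds with values here, the size of the new step therefore has no direct precedent, and no step clearly beyond the scatter is expected. A modest move towards a lower number is the expected direction, with the wide range reflecting the lack of precedent. The expected step is a 1.6-fold lower number from compound 2 to compound 4 (0.20 log units; within the scatter).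

A result at the limit of the assay also remains possible for compound 4. The estimate for compound 4 is 25000 nM, with an expected range of 8000 nM to 50000 nM.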

Compound 4, half-maximal inhibitory concentration: 21100 nM
Beside the measured number, compound 4's estimate is 1.2-fold (0.07 log units) above it; the measured number falls inside the stated range.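

In this assay, for the compounds shown here, the aromatic ring on the amino nitrogen is changed for the first time, and exchanging 1-methyl-1H-pyrazol-3-yl for 6-methoxypyridin-3-yl gives a 1.9-fold lower number from compound 2 to compound 4 (0.28 log units; within the scatter). Going by these compounds alone, this is the first step between two actual numbers, and it shows that this position accepts a six-membered aromatic ring carrying a methoxy group in place of a five-membered aromatic ring, with the result still a number and the step still within the scatter. Compound 4 therefore joins compound 2 as a readable value, whereas compound 1 and compound 3 remain limits of the assay: the limit of > 50000 nM in this assay, at which 2 of the 4 values shown sit.

Within the data shown here, the single step changes ring size, ring hetero atoms and the substituent together, so the contribution of each to the result remains unresolved. Also open, as far as these compounds go, is whether a dimethylamino group or a carboxylic acid in place of the methoxy group on the pyridine ring, or a morpholine ring on the amino nitrogen, would produce a step beyond the scatter.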